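Fluoro in Place of Trifluoromethyl: An Expected Loss

A few compounds are considered here, and "the series" means these few. Any claim that something is new, unique, unknown or untested is made for them only; others in the source may bear on it.

Compound 1, `Cc1ccc(C(=O)Nc2nc(Cl)c3cn(C(C)C)nc3n2)cc1`: in an assay on CHO cells for displacement of a labelled ligand from adenosine receptor A3 (Homo sapiens), read by scintillation counting, with a stated time of 3 h (a higher number here means a weaker inhibitor, a lower number a stronger inhibitor), compound 1 gives > 100000 nM, which is a limit of the assay and not a number.
Compound 2, `CC(C)n1cc2c(Cl)nc(NC(=O)c3ccc(C(F)(F)F)cc3)nc2n1`: in this assay compound 2 gives 10300 nM.

Compound 2 thus holds the only number shown; the one other value is a limit. Among the measured compounds shown here, the single measured step, an at least 9.7-fold lower number from compound 1 to compound 2 (0.98 log units; beyond the scatter), rests on (the limit of > 100000 nM in this assay, at which 1 of the 2 values shown sits), so its true size is open beyond that floor. Compound 3, `CC(C)n1cc2c(Cl)nc(NC(=O)c3ccc(F)cc3)nc2n1`, differs from compound 2 by fluoro in place of trifluoromethyl on an aromatic carbon. This change moves back toward a small substituent, as in compound 1, so that measured step bears on it, though in the reverse sense. The expected step of a 3.9-fold higher number from compound 2 to compound 3 (0.59 log units; beyond the scatter) is therefore toward a higher number, of a size not firmly fixed by the data. Compound 3 is expected to give about 40000 nM in this assay, between 10000 nM and 150000 nM, with a fair chance that only a limit is reported.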

Compound 3, inhibition constant: > 60000 nM
Compound 3 was reported as a limit; the forecaster's own chance of this, stated with the estimate: 40%; at least 1.5-fold (0.17 log units) between middle value and limit.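

The exchange of trifluoromethyl for fluoro, para to a large group, brings an at least 5.8-fold higher number from compound 2 to compound 3 (0.76 log units; beyond the scatter) in this assay, so the lower number of compound 2 does not carry over to this smaller halogen. Methyl and fluoro now both end at a limit at this position, and among the three compounds only compound 2, with trifluoromethyl, gives a number. The step between compound 1 and compound 3 cannot be read, and the true size of the step to compound 3 stays open beyond its floor: the limit of > 60000 nM in this assay, at which 1 of the 3 values shown sits.

The compounds shown leave open whether the lower number belongs to trifluoromethyl alone or would also come with a bromo or a trifluoromethoxy group at this place. With a single number among the three, they also give no order among the other substituents.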